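Antiproliferative notes on a pair of aryl-substituted nucleosides

The source may hold more compounds than are shown below. What is called first, only, known or untested is meant among the compounds shown, and "the series" means these compounds.

Compound 1 `O=c1[nH]cnc2c1c(-c1ccsc1)cn2[C@@H]1O[C@H](CO)[C@@H](O)[C@H]1O` carries thiophen-3-yl; compound 2 `O=c1[nH]cnc2c1c(-c1cc3ccccc3o1)cn2[C@@H]1O[C@H](CO)[C@@H](O)[C@H]1O` carries 1-benzofuran-2-yl on the same core; compound 3 `Cc1nc(N)c2c(-c3cc4ccccc4o3)cn([C@@H]3O[C@H](CO)[C@@H](O)[C@H]3O)c2n1` carries 1-benzofuran-2-yl on another core. In a functional assay on HepG2 cells (Homo sapiens) for antiproliferative activity, read by XTT assay, with a stated time of 72 h (a higher number here means a weaker inhibitor, a lower number a stronger inhibitor), compound 1 gives only the assay limit > 15000 nM. Compound 2 gives only the limit > 20000 nM. Compound 3 also gives only the limit > 20000 nM. The change thiophen-3-yl in place of 1-benzofuran-2-yl on an aromatic carbon gives a step that the two limits leave unreadable from compound 2 to compound 1, which stays unreadable because the limit of > 15000 nM in this assay, at which 1 of the 3 values shown sits, and the limit of > 20000 nM in this assay, at which 2 of the 3 values shown sit, cap both values. How the cores of compound 2 and compound 3 differ is not broken down here. Compound 4 `Cc1nc(N)c2c(-c3ccsc3)cn([C@@H]3O[C@H](CO)[C@@H](O)[C@H]3O)c2n1` carries the same change, (thiophen-3-yl in place of 1-benzofuran-2-yl on an aromatic carbon), at the same place. The step that the limit leaves unreadable from compound 3 to compound 4 is expected to remain unreadable at the limit. That estimate rests on compound 3 giving only the limit > 20000 nM. Compound 4 is expected at 25000 nM, between 8000 nM and 80000 nM.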

Compound 4, half-maximal inhibitory concentration: > 20000 nM
Compound 4 ended at the assay's limit (the forecaster's own chance of this, stated with the estimate: 85%); the middle value lies beyond the limit too.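

No step can be read between compound 3 and compound 4, as both values are limits. In this assay, the compounds shown leave open how thiophen-3-yl and 1-benzofuran-2-yl compare on either core.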